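Same substituent swap, second core: Substance-P receptor binding

This account rests on a few compounds, and the source may have more. Where it says the series, first, only, none or still open, it means among the compounds named here.

Measured compounds in an assay on IM-9 cells for displacement of a labelled ligand from Substance-P receptor (Homo sapiens), read by scintillation counting, with a stated time of 30 min; a lower number here means a stronger inhibitor, a higher number a weaker inhibitor:
Compound 1 `CC(=O)NCC(=O)N1CC[C@@H](C(=O)N(C)Cc2cc(C(F)(F)F)cc(C(F)(F)F)c2)[C@H](c2ccccc2)C1` gives 12 nM.
Compound 2 `CC(=O)N1CCC(C(=O)N2CC[C@@H](C(=O)N(C)Cc3cc(C(F)(F)F)cc(C(F)(F)F)c3)[C@H](c3ccccc3)C2)CC1` gives 0.098 nM.
Compound 3 `CC(=O)N1CCC(C(=O)N2CC[C@H](C(=O)N(C)Cc3cc(C(F)(F)F)cc(C(F)(F)F)c3)[C@@H](c3ccc(F)cc3C)C2)CC1` gives 0.047 nM.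

Compound 3 shows the lowest number of the three in this assay; compound 2 stands nearest to it with a higher number, and compound 1 stands furthest away. The difference between the cores of compound 2 and compound 3 is not broken down here. Compound 2 and compound 1 differ in a single place: acetamidomethyl in place of 1-acetylpiperidin-4-yl on a carbonyl carbon. That change gives a 120-fold higher number from compound 2 to compound 1 (2.09 log units; beyond the scatter).

Compound 4 `CC(=O)NCC(=O)N1CC[C@H](C(=O)N(C)Cc2cc(C(F)(F)F)cc(C(F)(F)F)c2)[C@@H](c2ccc(F)cc2C)C1` has not yet been measured. It differs from compound 3 by the same change, (acetamidomethyl in place of 1-acetylpiperidin-4-yl on a carbonyl carbon), and the place of the change is described in the same words as for the earlier pair. Going by the values given here, because a 120-fold higher number from compound 2 to compound 1 (2.09 log units; beyond the scatter) is large and only this one example of the change exists, the step is expected to be similar: a 120-fold higher number from compound 3 to compound 4 (2.08 log units; beyond the scatter). Compound 4 is accordingly estimated at 5.6 nM, expected to fall between 2 nM and 16 nM, with the wider uncertainty reflecting that compound 3 carries a different core from compound 2.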

Compound 4, half-maximal inhibitory concentration: 0.043 nM
Compound 4: middle estimate off by 130-fold (2.11 log units), on the high side; the measured number lies below the stated range.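

In this assay, putting acetamidomethyl in place of 1-acetylpiperidin-4-yl on the carbonyl carbon gives a 1.1-fold lower number from compound 3 to compound 4 (0.04 log units; within the scatter), so the two compounds on this core cannot be told apart. The large step seen on the core of compound 2 therefore does not carry over to the core of compound 3, and a step read on one core in this series cannot be taken as a guide to the other: the same change on two cores in this assay, a 120-fold higher number (2.09 log units; beyond the scatter) from compound 2 to compound 1 and a 1.1-fold lower number (0.04 log units; within the scatter) from compound 3 to compound 4, 130-fold (2.13 log units) apart, beyond the scatter of two such steps. This does not show which of the differences between the two cores lies behind the gap, and with a single pair on each core it gives no rule for any further core.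

On these data alone, it remains open whether a simple amine, a carboxylic acid or a longer chain on that carbonyl carbon would also separate the two cores. As far as these compounds go, it is equally open whether the core of compound 3 would stay as unresponsive to such groups as it does to this swap.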